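Removing a Silicon-Bearing Chain on Two Related Cores

This account rests on a few compounds, and the source may have more. Where it says the series, first, only, none or still open, it means among the compounds named here.

Of the compounds shown here, three have been measured in a functional assay on HepG2 cells (Homo sapiens) for antiproliferative activity, read by MTT assay, with a stated time of 72 h; a lower number here means a stronger inhibitor, a higher number a weaker inhibitor. Compound 1 `COCn1c(CC(O)(CO)CO)cc(=O)[nH]c1=O` reached only the limit of the assay, reported as > 100000 nM. Compound 2 `C[Si](C)(C)CCOCn1c(CC(O)(CO)CO)cc(=O)[nH]c1=O` likewise gave a limit rather than a number, > 100000 nM. Compound 3 `Cc1c(CC(O)COCc2ccccc2)n(COCC[Si](C)(C)C)c(=O)[nH]c1=O` also stopped at a limit, > 100000 nM. Compound 2 and compound 1 are linked by the change (a hydrogen atom in place of a group of 5 heavy atoms (4 carbon, 1 silicon; no ring), on a saturated chain carbon bound to an oxygen on a saturated carbon), and the step that the two limits leave unreadable from compound 2 to compound 1 cannot be given a size because both values sit at the limit of > 100000 nM in this assay, at which 3 of the 3 values shown sit.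

Compound 4 `COCn1c(CC(O)COCc2ccccc2)c(C)c(=O)[nH]c1=O` is not yet measured. It is made from compound 3 by the same change, (a hydrogen atom in place of a group of 5 heavy atoms (4 carbon, 1 silicon; no ring), on a saturated chain carbon bound to an oxygen on a saturated carbon), at the same place as before. How the core of compound 3 differs from that of compound 2 is not broken down here. In this assay the expected step is a step that the limit leaves unreadable from compound 3 to compound 4, set beside the earlier unreadable step; this expectation rests on (the limit of > 100000 nM in this assay, at which 3 of the 3 values shown sit), where every measured value stands. Compound 4 is therefore expected to give 150000 nM, most probably again as a limit, with a range from 50000 nM to 500000 nM.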

Compound 4, half-maximal inhibitory concentration: > 100000 nM
Compound 4: a limit, no number (the forecaster's own chance of this, stated with the estimate: 85%); the middle value is on the limit's open side.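

In this assay compound 4 gives > 100000 nM as a limit and not a number. Compound 3 also stands at a limit, so no step can be read from compound 3 to compound 4 or compared with the earlier one: the limit of > 100000 nM in this assay, at which 4 of the 4 values shown sit.

The compounds shown leave open whether removing the silicon-bearing chain changes activity on either core.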